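The source may report more compounds than this note shows. Statements on the series, on what has been measured and on what is new or still open speak of the compounds shown alone.

Of the compounds shown here, two sharing one core have been measured so far in a functional assay on MCF7 cells (Homo sapiens) for inhibition, read by MTT assay, with a stated time of 48 h, tested at 10 uM; on this read-out lower numbers stand for less inhibition of growth and higher numbers for more inhibition of growth at the one concentration tested. Compound 1 `Cc1oc2c([C@H]3CCN(C)C[C@H]3O)c(O)cc(O)c2c(=O)c1C(O)c1ccc([N+](=O)[O-])cc1` gives 4%, while compound 2 `Cc1oc2c([C@H]3CCN(C)C[C@H]3O)c(O)cc(O)c2c(=O)c1C(O)c1c(Cl)cccc1Cl` gives 33%, the higher of the two numbers. Compound 3 `Cc1oc2c([C@H]3CCN(C)C[C@H]3O)c(O)cc(O)c2c(=O)c1C(O)c1c(F)cccc1Cl` has not yet been measured. It differs from compound 2 in one place: fluoro in place of chloro on an aromatic carbon, which puts fluoro in place of chloro on an aromatic carbon, ortho to a large group and meta to a chloro group. Going by the values given here, only one measured step bears on this change: a number 29 percentage points higher from compound 1 to compound 2 (beyond the scatter), a modest step that came with 2,6-dichlorophenyl in place of 4-nitrophenyl. That swap replaced a whole substituted ring, whereas here a single atom changes and the other chloro stays. The expected result is a slight fall, a number 5 percentage points lower from compound 2 to compound 3 (within the scatter), probably within the scatter. Compound 3 is estimated at 28%, with an expected range of 12% to 45%.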

Compound 3, percent growth inhibition at one concentration: 41%
For compound 3 the middle estimate is 13 percentage points below the measured one, within the range that was stated.
By their numbers in this assay, from the lowest: compound 1; then compounds 2 and 3 (each within the scatter of the next).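

In this assay, fluoro in place of chloro on this aromatic carbon, ortho to a large group, gives a number 8 percentage points higher from compound 2 to compound 3 (within the scatter), so the two compounds cannot be told apart at this single concentration. The comparison with the nitro compound gives a number 37 percentage points higher from compound 1 to compound 3 (beyond the scatter), which came with 2-chloro-6-fluorophenyl in place of 4-nitrophenyl and shows that a clear difference from compound 1 does not require two chloro groups on the ring. No supporting data are available to explain these results.

On these data alone, it remains open whether a methoxy group or an amine on this same carbon would give a similar number, or whether a much larger or smaller number would follow. As far as these compounds go, the outcome of replacing the remaining chloro with fluoro, giving a 2,6-difluorophenyl ring, also remains open.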